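The source may hold more compounds than are shown below. What is called first, only, known or untested is meant among the compounds shown, and "the series" means these compounds.

Three compounds have been measured so far:

Compound 1 `O=C(O)CN1C(=O)/C(=C/c2nc3ccccc3n2Cc2ccc(F)cc2)SC1=S`: in a functional assay on MDA-MB-231 cells (Homo sapiens) for cytotoxicity, read by MTT assay, with a stated time of 48 h (on this read-out higher numbers stand for weaker inhibition and lower numbers for stronger inhibition), compound 1 gives 2620 nM.
Compound 2 `O=C(O)CN1C(=O)/C(=C/c2nc3ccccc3n2Cc2ccc(Cl)cc2)SC1=S`: in this assay compound 2 gives 5580 nM.
Compound 3 `O=C(O)CN1C(=O)/C(=C/c2nc3ccc(Cl)cc3n2Cc2ccccc2F)SC1=S`: in this assay compound 3 gives 9570 nM.

Compound 1 and compound 2 share a core and differ in one place: fluoro in place of chloro on an aromatic carbon. This change made a 2.1-fold lower number from compound 2 to compound 1 (0.33 log units; beyond the scatter). Compound 3 carries a different core; the difference between the two cores is not broken down here. The values of compound 3 and compound 2 lie within the usual scatter of each other, while the gap between compound 3 and compound 1 is beyond it.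

Compound 4 `O=C(O)CN1C(=O)/C(=C/c2nc3ccc(F)cc3n2Cc2ccccc2F)SC1=S` has not yet been measured. It differs from compound 3 by fluoro in place of chloro on an aromatic carbon. This is the same kind of change as that between compound 2 and compound 1, but not the same: there the place was on an aromatic carbon of a six-membered aromatic ring of carbon only, para to a large group, whereas here the place is on an aromatic carbon of a six-membered aromatic ring of carbon only, part of a fused or bridged system of two rings, meta to a fused ring and para to a fused ring. Because a 2.1-fold lower number from compound 2 to compound 1 (0.33 log units; beyond the scatter) was a modest step toward lower numbers, a step of similar or smaller size is expected here, though the different surroundings of the place make this less certain. Compound 4 is expected to show a 1.5-fold lower number from compound 3 to compound 4 (0.17 log units; within the scatter) in this assay. The estimate for compound 4 is 6500 nM, expected to fall between 3000 nM and 14000 nM.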

Compound 4, half-maximal inhibitory concentration: > 50000 nM
Compound 4: no number, only a limit (the forecaster's own chance of this, stated with the estimate: 5%); middle value at least 7.6-fold (0.88 log units) away from the limit.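

In this assay, putting fluoro in place of chloro on an aromatic carbon gave an at least 5.2-fold higher number from compound 3 to compound 4 (0.71 log units; beyond the scatter). Compound 4 gives > 50000 nM, which is a limit of the assay and not a number. The same swap therefore did not carry over from one core to the other, although these two pairs do not show why, and they show only that a step seen on one core need not hold on another: the same change on two cores in this assay, a 2.1-fold lower number (0.33 log units; beyond the scatter) from compound 2 to compound 1 and an at least 5.2-fold higher number (0.71 log units; beyond the scatter) from compound 3 to compound 4, at least 11-fold (1.04 log units) apart, beyond the scatter of two such steps

The compounds shown leave open whether the opposite outcome belongs to the place of the swap, which differs between the two pairs, or to the rest of the core, and a chloro and fluoro pair placed alike on both cores would be needed to separate the two. Going by these compounds, it also remains open how other groups would behave at the place on the core of compound 3, such as a methyl group, a methoxy group or a nitrile, and whether any of them would give a measured number rather than a limit.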